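A few compounds are considered here, and "the series" means these few. Any claim that something is new, unique, unknown or untested is made for them only; others in the source may bear on it.

Measured in an ADME assay on microsomes from liver (Homo sapiens) for metabolic stability, with a stated time of 10 min; a lower number here means that less of the compound is left, a higher number that more of the compound is left:
Compound 1 `O=C(O)C12CCC(C(=O)N3CC[C@](c4ccc(C(F)(C(F)(F)F)C(F)(F)F)cc4)(S(=O)(=O)c4ccc(F)cc4)C3)(CC1)CC2`: 100%
Compound 2 `NC(=O)[C@H]1CC[C@H](C(=O)N2CC[C@](c3ccc(C(F)(C(F)(F)F)C(F)(F)F)cc3)(S(=O)(=O)c3ccc(F)cc3)C2)CC1`: 100%

Compound 2 stands level with compound 1 in this assay, and nothing measured separates them. Compound 3 `CCC1(C(=O)N2CC[C@](c3ccc(C(F)(C(F)(F)F)C(F)(F)F)cc3)(S(=O)(=O)c3ccc(F)cc3)C2)CCS(=O)(=O)CC1` keeps the shared core and changes only the group on the carbonyl carbon: 4-ethyl-1,1-dioxothian-4-yl in place of 4-carbamoylcyclohexyl on a carbonyl carbon. Thus 4-ethyl-1,1-dioxothian-4-yl enters in place of 4-carbamoylcyclohexyl.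

Within the data shown here, one measured step bears on this, a swap at the same place: no change at the digits printed from compound 1 to compound 2 (within the scatter). Among the measured compounds shown here, that single step is the whole of the evidence, and no measured compound carries the entering group. A step beyond the scatter therefore is not expected in this assay, though any departure would more likely be downward, since compound 2 gives 100%. The expected step is a number 5 percentage points lower from compound 2 to compound 3 (within the scatter). For compound 3 the estimated value is 95%, with an expected range of 78% to 100%.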

Compound 3, percent of the compound remaining: 3%
Beside the measured number, compound 3's estimate is 92 percentage points above it; the measured number lies below the stated range.
By their numbers in this assay, from the lowest: compound 3; then compounds 1 and 2 (each within the scatter of the next).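

Compound 3 shows that the group on this carbonyl carbon can set the outcome in this assay: 4-ethyl-1,1-dioxothian-4-yl in place of 4-carbamoylcyclohexyl gives a number 97 percentage points lower from compound 2 to compound 3 (beyond the scatter), and the comparison with the group of compound 1 gives a number 97 percentage points lower from compound 1 to compound 3 (beyond the scatter). The shared core therefore does not by itself keep the read-out high, which compounds 1 and 2 alone could not reveal. Nothing measured here accounts for the drop.

The compounds shown leave open whether the ethyl chain or the 1,1-dioxothian ring goes with the low number: the two enter together in compound 3. A 1,1-dioxothian-4-yl group without the ethyl chain, or a 4-ethylcyclohexyl group, on the same carbonyl carbon would separate the two.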